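The source may hold more compounds than are shown below. What is called first, only, known or untested is meant among the compounds shown, and "the series" means these compounds.

Measured so far:
Compound 1, `Nc1nc(O)c2nc(Br)n(C3CCCc4cccc(Br)c43)c2n1`, gives 1310 nM in an assay on HUT-78 cells for inhibition of phosphodiesterase 7 (Homo sapiens); on this read-out lower numbers stand for stronger inhibition and higher numbers for weaker inhibition.
Compound 2, `Nc1nc(O)c2nc(Br)n(C3CCCc4ccc([N+](=O)[O-])cc43)c2n1`, gives 2310 nM in this assay.

Of these two numbers, compound 2 carries the higher one, yet its gap to compound 1 lies within the usual scatter of repeated measurements, so the two compounds cannot be told apart on this evidence. Compound 3, `COc1ccc2c(c1)C(n1c(Br)nc3c(O)nc(N)nc31)CCC2`, has not yet been measured. It differs from compound 2 in one place: methoxy in place of nitro on an aromatic carbon. For the measured compounds named here, no step between measured compounds covers such a change, so nothing in these two results says how a methoxy will fare against a nitro on that aromatic carbon. The expected step is therefore small, in either direction, and not beyond the scatter. The estimated step of a 1.3-fold lower number from compound 2 to compound 3 (0.11 log units; within the scatter) expresses that view. Compound 3 is expected to give about 1800 nM in this assay, with a range from 600 nM to 5500 nM.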

Compound 3, half-maximal inhibitory concentration: 4220 nM
Beside the measured number, compound 3's estimate is 2.3-fold (0.37 log units) below it; the range from low to high includes it.
By their numbers in this assay, from the lowest: compounds 1, 2 and 3 (each within the scatter of the next, the first and the last beyond it).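

In this assay the change of methoxy in place of nitro gives a 1.8-fold higher number from compound 2 to compound 3 (0.26 log units; within the scatter) and so lies within the usual scatter of repeated measurements. For the compounds shown here, this is the first direct reading at this position, on an aromatic carbon of a six-membered aromatic ring of carbon only, and on this evidence the two groups cannot be told apart there. The swap of nitro for methoxy thus leaves no measurable mark in this assay, although the two groups differ in their atoms. No measured data bear on why this is so.

From the compounds shown here alone, whether an amine or a carboxylic acid on that same aromatic carbon would also stay within the scatter remains open. So does the question of whether methoxy and nitro would stay indistinguishable on another carbon of that ring.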